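The source may hold more compounds than are shown below. What is called first, only, known or untested is meant among the compounds shown, and "the series" means these compounds.

In a functional assay on HEK293 cells for agonist activity at Free fatty acid receptor 1 (Homo sapiens), read by fluorescence and calcium flux (a higher number here means that more compound is needed for the effect, a lower number that less compound is needed), compound 1 `CC#CC(CC(=O)O)c1ccc(OCc2ccc(C(=O)N3CCN(c4ccccc4)CC3)s2)cc1` gives 72 nM, compound 2 `CC#CC(CC(=O)O)c1ccc(OCc2ccc(C(=O)N3CCN(Cc4ccccc4)CC3)s2)cc1` gives 155 nM, and compound 3 `CC#CC(CC(=O)O)c1ccc(OCc2ccc(C(=O)N3CCN(c4ccccn4)CC3)s2)cc1` gives 138 nM. Compound 3 thus stands second highest of the three numbers, with a 1.1-fold lower number from compound 2 to compound 3 (0.05 log units; within the scatter) and a 1.9-fold higher number from compound 1 to compound 3 (0.28 log units; within the scatter) both within the scatter. Compound 4 `CC#CC(CC(=O)O)c1ccc(OCc2ccc(C(=O)N3CCN(c4ccc(C(C)(C)C)cc4)CC3)s2)cc1` differs from compound 3 by 4-(tert-butyl)phenyl in place of pyridin-2-yl on an amine nitrogen in a ring. The closest guide is a 1.9-fold higher number from compound 1 to compound 3 (0.28 log units; within the scatter), which the new change reverses while also adding the tert-butyl part of 4-(tert-butyl)phenyl; a 2.2-fold higher number from compound 1 to compound 2 (0.33 log units; beyond the scatter) shows that another change on the same ring nitrogen moved the number only modestly. Compound 4 is therefore expected to show a 1.7-fold lower number from compound 3 to compound 4 (0.24 log units; within the scatter) in this assay, a small step downward. The estimate for compound 4 is 80 nM, with a range from 30 nM to 250 nM.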

Compound 4, half-maximal effective concentration: 417 nM
The estimate for compound 4 lay 5.2-fold (0.72 log units) below the measured number; the measured number lies above the stated range.
By their numbers in this assay, from the lowest: compounds 1, 3 and 2 (each within the scatter of the next, the first and the last beyond it); then compound 4.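

In this assay, tert-butyl in place of hydrogen on an aromatic carbon gives a 5.8-fold higher number from compound 1 to compound 4 (0.76 log units; beyond the scatter) and so far the largest step at this ring nitrogen. The 4-(tert-butyl)phenyl group also stands apart from the other two groups, with a 3.0-fold higher number from compound 3 to compound 4 (0.48 log units; beyond the scatter) and a 2.7-fold higher number from compound 2 to compound 4 (0.43 log units; beyond the scatter) both beyond the scatter, so this position does not accept every added group equally. Nothing available explains this rise.

On these data alone, whether a smaller methyl group on the same phenyl ring would raise the number less stays open.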